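The source may hold more compounds than are shown below. What is called first, only, known or untested is meant among the compounds shown, and "the series" means these compounds.

The measured compounds:

Compound 1, `O=C(/C=C\Nc1ccc(O)cc1)c1cn(-c2ccccc2)nc1-c1ccc(F)cc1`, gives 1900 nM in a functional assay on HT-29 cells (Homo sapiens) for antiproliferative activity, read by MTT assay, with a stated time of 48 h; a higher number here means a weaker inhibitor, a lower number a stronger inhibitor.
Compound 2, `COc1ccc(N/C=C\C(=O)c2cn(-c3ccccc3)nc2-c2ccc(F)cc2)cc1`, gives 3200 nM in this assay.
Compound 3, `COc1cc(-c2nn(-c3ccccc3)cc2C(=O)/C=C\Nc2ccc(O)cc2)cc(OC)c1OC`, gives 2500 nM in this assay.

Compound 1 and compound 2 differ in one place: methyl in place of hydrogen on an oxygen on an aromatic ring. This change produced a 1.7-fold higher number from compound 1 to compound 2 (0.23 log units; within the scatter), so the two values sit together within the usual spread of such measurements, and nothing can be said about the order of compound 1 and compound 2.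

Compound 3 carries the same (4-hydroxyphenyl)amino group as compound 1, but the rest of the molecule is changed in more than one place; the difference between the two cores is not broken down here. Its value in this assay lies within the scatter of both compound 1 and compound 2, so the three measured compounds cannot be separated from one another.

Compound 4, `COc1ccc(N/C=C\C(=O)c2cn(-c3ccccc3)nc2-c2cc(OC)c(OC)c(OC)c2)cc1`, has not yet been measured. It differs from compound 3 as follows: methyl in place of hydrogen on an oxygen on an aromatic ring. The place line reads word for word as it does for the pair of compound 1 and compound 2, so this is the same change made on the core of compound 3.

Compound 4 is expected to give a step of about a 1.6-fold higher number from compound 3 to compound 4 (0.20 log units; within the scatter), resting on the earlier step from compound 1 to compound 2, which stayed within the scatter. The estimate for compound 4 is therefore 4000 nM, with a likely range from 2000 nM to 8500 nM, because compound 3 gives 2500 nM and the same change on compound 1 moved the number only slightly.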

Compound 4, half-maximal inhibitory concentration: 5780 nM
For compound 4 the middle estimate is 1.4-fold (0.16 log units) below the measured one, within the range that was stated.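

In this assay the change from 4-hydroxyphenyl to 4-methoxyphenyl on the core of compound 3 gave a 2.3-fold higher number from compound 3 to compound 4 (0.36 log units; beyond the scatter) and this modest step lies beyond the scatter, whereas the same change on the core of compound 1 stayed within it. This difference in standing does not show that the change acts more strongly on one core than on the other, and two pairs cannot show that it would carry to further cores in the series; the other new step, 3,4,5-trimethoxyphenyl in place of 4-fluorophenyl, gave a 1.8-fold higher number from compound 2 to compound 4 (0.26 log units; within the scatter) and so leaves no order between those two compounds. What the result does show is that the change moved the number the same way on both cores, by amounts that cannot be told apart: the same change on two cores in this assay, a 1.7-fold higher number (0.23 log units; within the scatter) from compound 1 to compound 2 and a 2.3-fold higher number (0.36 log units; beyond the scatter) from compound 3 to compound 4, 1.4-fold (0.14 log units) apart, within the scatter of two such steps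

The compounds shown leave open how an ethoxy group, an amine or a carboxylic acid in place of the methoxy group would read in this assay. As far as these compounds go, it also remains open whether the step would hold on a core bearing a group such as 4-chlorophenyl in place of 4-fluorophenyl or 3,4,5-trimethoxyphenyl.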